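From 2-ethylphenyl to 2,3-dichlorophenyl on a shared core

This account rests on a few compounds, and the source may have more. Where it says the series, first, only, none or still open, it means among the compounds named here.

Among the compounds with values here, in a functional assay (muscle tissue) with Cavia porcellus as the target (on this read-out higher numbers stand for an effect only at larger amounts of compound and lower numbers for an effect already at smaller amounts), compound 1 (`COC(=O)C1=C(C)N=C(C)/C(=C(\O)OC)C1c1ccccc1N`) gives 39800 nM, whereas compound 2 (`CCc1ccccc1C1C(C(=O)OC)=C(C)N=C(C)/C1=C(\O)OC`) gives 6.46 nM, the lower of the two numbers so far. Compound 3 (`COC(=O)C1=C(C)N=C(C)/C(=C(\O)OC)C1c1cccc(Cl)c1Cl`) has 2,3-dichlorophenyl in place of 2-ethylphenyl on a saturated ring carbon. Within the data shown here, only one measured step bears on this change: a 6200-fold lower number from compound 1 to compound 2 (3.79 log units; beyond the scatter), a large step in which ethyl replaced amino on an aromatic carbon. Among the measured compounds shown here, it shows that one change on this aromatic ring can move the number far, but it involved a different swap, and no measured compound carries chlorine. Compound 3 shares with compound 2 the absence of the amino group, so no step beyond the scatter is expected in this assay, though with wide uncertainty. The expected change is a 1.3-fold lower number from compound 2 to compound 3 (0.11 log units; within the scatter). Compound 3 is estimated at 5 nM, within an expected range of 0.8 nM to 40 nM.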

Compound 3, half-maximal effective concentration: 19.1 nM
For compound 3 the middle estimate is 3.8-fold (0.58 log units) below the measured one, and the stated range covers the measured number.
By their numbers in this assay, from the lowest: compound 2; then compound 3; then compound 1.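

In this assay, replacing 2-ethylphenyl with 2,3-dichlorophenyl gives a 3.0-fold higher number from compound 2 to compound 3 (0.47 log units; beyond the scatter), a modest step, while replacing 2-aminophenyl with the same group gives a 2100-fold lower number from compound 1 to compound 3 (3.32 log units; beyond the scatter), a large one. At this position, then, two quite different groups, one with an ethyl chain and one with two chlorine atoms, both leave the number far lower than the 2-aminophenyl group does, and among these three compounds only compound 1 stands apart. Nothing shown here gives a reason for either step.

On these data alone, it remains open whether a single chlorine, a methoxy group or a longer chain such as propyl on this aromatic ring would stay close to compound 2 and compound 3 or move towards compound 1. A 2-hydroxyphenyl or 2-(dimethylamino)phenyl group would also help to show how special the amino group is.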